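The source may report more compounds than this note shows. Statements on the series, on what has been measured and on what is new or still open speak of the compounds shown alone.

Measured so far:
compound 1: `O=C(CN(c1ncnc2c1ncn2C1CCCCO1)C1CC1)N[C@@H](CO)C(=O)OCc1ccccc1`; 27.8%
compound 2: `CC(C)(C)OC(=O)NCCCC[C@H](NC(=O)CN(c1ncnc2c1ncn2C1CCCCO1)C1CC1)C(=O)OCc1ccccc1`; 18.3%

In a functional assay on the whole organism (Tail, strain ICR) with Mus musculus as the target, in the tail flick test, with a stated time of 30 min, at a dose of 25 umol/kg by the oral route (on this read-out lower numbers stand for a weaker effect and higher numbers for a stronger effect at the one dose given), compound 1 gives 27.8%, and compound 2 gives 18.3%. For the measured compounds named here, compound 2 holds the lower of the two numbers, yet the only measured step, a number 9.5 percentage points lower from compound 1 to compound 2 (within the scatter), lies within the scatter, so the two compounds cannot be set apart on this read-out.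

Compound 3, `N=C(N)NCCC[C@H](NC(=O)CN(c1ncnc2c1ncn2C1CCCCO1)C1CC1)C(=O)OCc1ccccc1`, differs from compound 2 in one place: a group of 4 heavy atoms (1 carbon, 3 nitrogen; no ring) in place of a group of 9 heavy atoms (6 carbon, 1 nitrogen, 2 oxygen; no ring), on a saturated chain carbon, four bonds along the chain from an amide-type nitrogen and a carbonyl carbon. Going by the values given here, no measured step exchanges this pair of groups; the one step available sits at another place on the chain and was itself within the scatter. Taken on its own, that gives no ground for a step beyond the scatter in this assay in either direction, so the step expected is a number 3.7 percentage points higher from compound 2 to compound 3 (within the scatter), small and uncertain. Compound 3 is estimated at 22%, within a range of 5% to 45%.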

Compound 3, a percentage reported as activity, at one dose (the size of the read-out at that dose, not a potency): 34.3%
For compound 3 the middle estimate is 12.3 percentage points below the measured one, and the stated range covers the measured number.
By their numbers in this assay, from the lowest: compounds 2, 1 and 3 (each within the scatter of the next, the first and the last beyond it).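

In this assay, for the compounds shown here, the group of 4 heavy atoms (1 carbon, 3 nitrogen) in place of ((tert-butoxycarbonyl)amino)methyl, on a saturated chain carbon four bonds along the chain from an amide-type nitrogen and a carbonyl carbon, gives a number 16 percentage points higher from compound 2 to compound 3 (beyond the scatter), the first step that clears the scatter, though only modestly. The chain end at this position can therefore separate two compounds, but the comparison with the hydroxy side chain shows a number 6.5 percentage points higher from compound 1 to compound 3 (within the scatter), so compound 3 is not set apart from compound 1. Nothing available accounts for the step.

Going by these compounds, whether a free amine or a carboxylic acid at this chain end would read like compound 3 or like compound 2 remains open. So does the effect of a longer chain carrying the same end group.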